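A few compounds are considered here, and "the series" means these few. Any claim that something is new, unique, unknown or untested is made for them only; others in the source may bear on it.

Measured in an ADME assay on MDCK cells (Canis lupus familiaris) for cytotoxicity, read by CCK-8 assay, with a stated time of 5 days; on this read-out higher numbers stand for lower toxicity in this test and lower numbers for higher toxicity in this test:

- Compound 1 `O=C(O)[C@H]1C2CCC(CC2)[C@@H]1Nc1nc(-c2c[nH]c3ncc(F)cc23)nc2c1CCCC2`: > 50000 nM (a limit of the assay, not a number)
- Compound 2 `O=C(O)[C@H]1C2CCC(CC2)[C@@H]1Nc1nc(-c2c[nH]c3ncc(F)cc23)nc2ccsc12`: 1500 nM
- Compound 3 `O=C(O)[C@H]1C2CCC(CC2)[C@@H]1Nc1nc(-c2c[nH]c3ncc(F)cc23)nc2c1SCC2`: 4500 nM

For the measured compounds named here, the result for compound 1 (> 50000 nM) is a limit, so only two of the three compounds have actual numbers to compare. Of these, compound 2 (1500 nM) has the lower. Compound 3 (4500 nM) stands higher, by more than the usual scatter.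

The next compound to be tested is compound 4 `N#Cc1csc2c(N[C@H]3C4CCC(CC4)[C@@H]3C(=O)O)nc(-c3c[nH]c4ncc(F)cc34)nc12`. It keeps the framework of compound 2 but has cyano in place of hydrogen on an aromatic carbon, on a five-membered aromatic ring with 1 sulfur, two ring bonds from the ring sulfur (cyano in place of hydrogen on an aromatic carbon).

Going by the values given here, no measured pair differs in one place only, so the series offers no direct guide to this change. The expectation therefore starts from compound 2 (1500 nM), with only a slight lean towards a higher number. The expected step of a 1.7-fold higher number from compound 2 to compound 4 (0.22 log units; within the scatter) is small and stays within the scatter. In this assay the estimated value for compound 4 is 2500 nM, expected to fall between 700 nM and 12000 nM when measured.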

Compound 4, half-maximal cytotoxic concentration: 700 nM
Estimate against measurement, compound 4: 3.6-fold (0.55 log units) above, within the range that was stated.
By their numbers in this assay, from the lowest: compound 4; then compound 2; then compound 3. At a limit, above all of these: compound 1.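

In this assay, for the compounds shown here, cyano in place of hydrogen on an aromatic carbon of the five-membered aromatic ring with 1 sulfur, two ring bonds from the ring sulfur, gives the first change in one place that can be read: a 2.1-fold lower number from compound 2 to compound 4 (0.33 log units; beyond the scatter). The step is modest but beyond the usual scatter, so this position is not indifferent to substitution, and the change moves the read-out in the direction of higher toxicity in this test, with compound 4 at 700 nM. Nothing measured here bears on why the number moves with this change.

Going by these compounds, with only hydrogen and cyano to compare at this position, it remains open whether a methyl group or an amine in the same place would shift the number in the same direction, by a similar amount, or not at all. On these data alone, it also remains open whether cyano would have a comparable effect on the different cores of compound 1 and compound 3, or whether this step belongs to the core of compound 2 alone.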